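A few compounds are considered here, and "the series" means these few. Any claim that something is new, unique, unknown or untested is made for them only; others in the source may bear on it.

Measured in a functional assay on KB cells (Homo sapiens) for inhibition, read by MTT assay, with a stated time of 24 h, tested at 1 ug/mL; a lower number here means less inhibition of growth, a higher number more inhibition of growth at the concentration tested:
compound 1 `O=C(O)CCCCC(CCSC(=O)c1ccccc1)SC(=O)c1ccccc1`: 0.68%
compound 2 `O=C(CCCCC1CCSS1)Nc1cccc(C(F)(F)F)c1`: 9.5%
compound 3 `O=C(CCCCC1CCSS1)Nc1ccc(Cl)cn1`: 0.76%

Compound 1 stands within the scatter of both other compounds, so this assay does not separate these three at the concentration tested. Compound 4 `O=C(CCCCC(CCSC(=O)c1ccccc1)SC(=O)c1ccccc1)Nc1ccccc1Cl` has (2-chlorophenyl)amino in place of hydroxy on a carbonyl carbon and is otherwise the same as compound 1. Among the measured compounds shown here, no measured pair shows this change alone. Compound 2 at 9.5% and compound 3 at 0.76% also carry an aromatic ring on an amide, yet neither stands apart from compound 1 at 0.68% in these numbers. The expected step is a number 5.3 percentage points higher from compound 1 to compound 4 (within the scatter) towards more inhibition of growth, which stays within the scatter. Compound 4 is estimated at 6% with an expected range from 0% to 25% in this measurement.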

Compound 4, percent growth inhibition at one concentration: 3.05%
The estimate for compound 4 lay 3 percentage points above the measured number; the range from low to high includes it.
By their numbers in this assay, from the lowest: compounds 1, 3, 4 and 2 (each within the scatter of the next).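

In this assay, among the compounds shown here, the single change at this position can now be read: (2-chlorophenyl)amino in place of hydroxy on a carbonyl carbon gives a number 2.4 percentage points higher from compound 1 to compound 4 (within the scatter) and does not separate the two compounds. The position therefore takes this added aromatic ring with no readable change in growth inhibition at the concentration tested. No available evidence bears on this result.

Still open, on these data alone, is whether a simple amine, an unsubstituted phenylamino group or a longer chain on this carbonyl carbon would stand apart from compound 1.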